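Swapping a Methyl for a Chloro in Compound 1

The source may report more compounds than this note shows. Statements on the series, on what has been measured and on what is new or still open speak of the compounds shown alone.

For the measured compounds named here, in an ADME assay on the whole organism (Rattus norvegicus, strain Sprague-Dawley) for metabolic stability, at a dose of 2 mg/kg by the intravenous route (a lower number here means that the compound disappears faster, a higher number that the compound lasts longer), compound 1 `Cc1cc(C(F)(F)F)ccc1-c1cc2cnn([C@@H](CC(C)C)c3ccc(C(=O)NCCC(=O)O)cc3)c2cc1C` gives 1.6 h and so holds the lower of the two numbers measured so far. Compound 2 `Cc1cc(C(F)(F)F)ccc1-c1cc2cn([C@@H](CC(C)C)c3ccc(C(=O)NCCC(=O)O)cc3)nc2cc1C` reaches 3.7 h in this assay as well, a gap that lies beyond the usual scatter of repeated measurements.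

Compound 3 `Cc1cc2c(cnn2[C@@H](CC(C)C)c2ccc(C(=O)NCCC(=O)O)cc2)cc1-c1ccc(C(F)(F)F)cc1Cl` has not yet been measured. It differs from compound 1 in a single place (chloro in place of methyl on an aromatic carbon), which lies ortho to a large group and meta to a trifluoromethyl group. Put another way, a 2-methyl-4-(trifluoromethyl)phenyl becomes a 2-chloro-4-(trifluoromethyl)phenyl, while the rest of the molecule stays the same.

Going by the values given here, no measured pair here shows what this exchange does, so any forecast is rough. The estimated step of a 1.2-fold higher number from compound 1 to compound 3 (0.07 log units; within the scatter) is small, leans slightly towards a longer half-life and is expected to stay within the usual scatter. In this assay compound 3 is expected to give 1.9 h with an estimated range of 0.9 h to 4 h for its half-life.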

Compound 3, half-life: 3.6 h
Compound 3: the middle estimate sits 1.9-fold (0.28 log units) below what was measured, within the range that was stated.
By their numbers in this assay, from the lowest: compound 1; then compounds 3 and 2 (each within the scatter of the next).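

Replacing the methyl of the 2-methyl-4-(trifluoromethyl)phenyl with a chloro gives a 2.3-fold higher number from compound 1 to compound 3 (0.35 log units; beyond the scatter) in this assay. For the compounds shown here, this is the first measured step at this position, and it shows that the half-life in the rat responds to a change of a single heavy atom on this aromatic carbon, even though the change adds no ring, no charge and no hydrogen-bond donor or acceptor. Going by these compounds alone, it is still only one pair of compounds, and nothing measured here bears on why the half-life differs between them.

The compounds shown leave open whether a fluoro, a nitrile or a methoxy group on this same aromatic carbon would give a half-life closer to that of the methyl or to that of the chloro. They also leave open whether the same exchange of methyl for chloro would produce a step of similar size on compound 2, whose core differs from that of compound 1 and where the half-life starts from a different number.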